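Dodecyloxy Chain in Place of the Aminobutyl Group

The compounds below may be only part of what the source reports. "The series", "measured", "known", "first", "only" and "open" are said of these compounds alone.

In an assay (Cricetulus griseus) for inhibition of aldehyde dehydrogenase, mitochondrial (Homo sapiens) (on this read-out higher numbers stand for weaker inhibition and lower numbers for stronger inhibition), compound 1 `NCCCCCCOc1ccc2c(=O)c(-c3ccc(O)cc3)coc2c1` gives 100 nM, while compound 2 `NCCCCOc1ccc2c(=O)c(-c3ccc(O)cc3)coc2c1` gives 250 nM, the higher of the two numbers. Within the data shown here, the one step measured so far reads a 2.5-fold higher number from compound 1 to compound 2 (0.40 log units; beyond the scatter). Compound 3 `CCCCCCCCCCCCOc1ccc2c(=O)c(-c3ccc(O)cc3)coc2c1` differs from compound 2 by octyl in place of amino on a saturated chain carbon, four bonds along the chain from an oxygen on an aromatic ring. Among the measured compounds shown here, only that chain-shortening step bears on the change, and no measured step removes the amino group, so the direction remains open. The step from compound 2 to compound 3 is expected to be a 1.3-fold lower number from compound 2 to compound 3 (0.10 log units; within the scatter). Compound 3 is estimated at 200 nM, with a range from 40 nM to 1500 nM.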

Compound 3, half-maximal inhibitory concentration: > 9000 nM
Compound 3: a limit, no number; the forecaster's own chance of this, stated with the estimate: 8%; middle value at least 45-fold (1.65 log units) from the limit.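

Compound 3 stands at a limit of the assay, not at a number: the limit of > 9000 nM in this assay, at which 1 of the 3 values shown sits. Octyl in place of amino gives an at least 36-fold higher number from compound 2 to compound 3 (1.55 log units; beyond the scatter), and hexyl in place of amino gives an at least 90-fold higher number from compound 1 to compound 3 (1.95 log units; beyond the scatter). Among these compounds, both steps are large, whereas the one step between the two amino compounds is modest, so this place tolerates a change of chain length with the amino group kept far better than this change.

The change alters both the amino group and the chain length, and the compounds shown do not separate the two. A hexyl chain without an amine, or a dodecyl chain carrying an amine or a carboxylic acid, would bear on that question.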